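The compounds below may be only part of what the source reports. "The series", "measured", "known", "first", "only" and "open" are said of these compounds alone.

Among the measured compounds shown here, in an assay on isolated protein (Mus musculus) for inhibition of IL15-IL15 receptor (Homo sapiens), read by resazurin assay, with stated times of 30 min and 2.5 days (a higher number here means a weaker inhibitor, a lower number a stronger inhibitor), compound 2 `CCCOc1ccc(NC(=O)CCCCCCCSc2nnc(Cc3nn(C)c(=O)c4ccccc34)n2C)cc1` gives 1600 nM, the lower of the two numbers measured so far. Compound 1 `Cn1c(Cc2nn(C)c(=O)c3ccccc23)nnc1SCCCCCCCC(=O)Nc1ccc(O)cc1O` gives 17000 nM in the same test. For the measured compounds named here, the single measured step, an 11-fold lower number from compound 1 to compound 2 (1.03 log units; beyond the scatter), shows how much the group on the amide-type nitrogen can move the number. Compound 3 `Cn1c(Cc2nn(C)c(=O)c3ccccc23)nnc1SCCCCCCCC(=O)Nc1ccc(Cl)cc1Cl` differs from compound 2 by 2,4-dichlorophenyl in place of 4-propoxyphenyl on an amide-type nitrogen. Going by the values given here, only that one step bears on this change, and it went from 2,4-dihydroxyphenyl to 4-propoxyphenyl rather than to a chlorine-bearing ring, so it sets the scale of what a swap at this nitrogen can do without fixing its direction. A modest move toward a higher number, a 1.9-fold higher number from compound 2 to compound 3 (0.27 log units; within the scatter), is the expectation. Compound 3 is therefore estimated to give about 3000 nM in this assay, with a range from 800 nM to 12000 nM.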

Compound 3, half-maximal inhibitory concentration: 1900 nM
Beside the measured number, compound 3's estimate is 1.6-fold (0.20 log units) above it; measured number inside the range.
By their numbers in this assay, from the lowest: compounds 2 and 3 (each within the scatter of the next); then compound 1.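

In this assay, the step of a 1.2-fold higher number from compound 2 to compound 3 (0.07 log units; within the scatter) lies within the scatter, so 4-propoxyphenyl and 2,4-dichlorophenyl cannot be told apart at this amide-type nitrogen, even though one ring carries a hydrogen-bond acceptor and the other carries none. The second new step, an 8.9-fold lower number from compound 1 to compound 3 (0.95 log units; beyond the scatter), lies beyond the scatter, so among these three compounds, two differently substituted rings both give a clearly lower number than 2,4-dihydroxyphenyl. No measurement shown here explains why these rings behave alike or why compound 1 stands apart.

As far as these compounds go, it remains open how a plain phenyl ring, or a ring bearing a single hydroxyl, an amine or a carboxylic acid, would behave at this nitrogen. Also open, from the compounds shown here alone, is whether a shorter or longer chain would move the number.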